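The source may hold more compounds than are shown below. What is called first, only, known or untested is meant among the compounds shown, and "the series" means these compounds.

Compound 1 `COc1ccc(-c2c(S(=O)(=O)c3cc(F)cc(F)c3)cnc3cc(F)ccc23)cc1`: 1.51 mL/min in an ADME assay on microsomes from liver (Homo sapiens) for metabolic stability, tested at 2.5 uM; on this read-out lower numbers stand for slow clearance and higher numbers for fast clearance
Compound 2 `COc1ccc(-c2c(S(=O)(=O)c3ccc(F)c(Cl)c3)cnc3cc(F)ccc23)cc1`: 1.08 mL/min in this assay
Compound 3 `COc1ccc(-c2c(S(=O)(=O)c3cccc(C#N)c3)cnc3cc(F)ccc23)cc1`: 0.92 mL/min in this assay

In this assay compound 1 gives the highest of the three numbers, yet its separation from the others is small: the step of a 1.4-fold lower number from compound 1 to compound 2 (0.15 log units; within the scatter) and the step of a 1.6-fold lower number from compound 1 to compound 3 (0.22 log units; within the scatter) both fall within the scatter of the measurement, as does the step of a 1.2-fold lower number from compound 2 to compound 3 (0.07 log units; within the scatter). The three measured compounds therefore cannot be ordered against one another on this read-out.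

Compound 4 `O=S(=O)(c1cc(F)cc(F)c1)c1cnc2cc(F)ccc2c1-c1cccc(Cl)c1` has not been measured. It differs from compound 1 in one place: 3-chlorophenyl in place of 4-methoxyphenyl on an aromatic carbon. Every measured step concerns the group on the sulfonyl sulfur, while compound 1 and compound 4 share that group and differ instead at the aromatic carbon opposite the ring nitrogen of the shared core. Within the data shown here, no measured step bears on this change, so nothing in the data points to a step beyond the scatter in either direction.

The estimate for compound 4 is therefore close to the number of compound 1, with a step of a 1.0-fold lower number from compound 1 to compound 4 (0.00 log units; within the scatter) expected in this assay, and a wide range. Compound 4 is expected to give about 1.5 mL/min, between 0.7 mL/min and 3.2 mL/min.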

Compound 4, intrinsic clearance in a liver preparation (reported as CLH), per the amount of preparation that the assay uses: 0.22 mL/min
Compound 4: middle estimate off by 6.8-fold (0.83 log units), on the high side; the measured number lies below the stated range.
By their numbers in this assay, from the lowest: compound 4; then compounds 3, 2 and 1 (each within the scatter of the next).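

In this assay, putting 3-chlorophenyl in place of 4-methoxyphenyl on the aromatic carbon opposite the ring nitrogen gives a 6.9-fold lower number from compound 1 to compound 4 (0.84 log units; beyond the scatter). Among these compounds, this is the only step in the set that lies beyond the scatter, and it points towards slow clearance, whereas the three exchanges of the group on the sulfonyl sulfur among compounds 1, 2 and 3 all stayed within the scatter. The shown data thus mark this aromatic carbon as a place where a single exchange can move the read-out clearly, but no measurement at hand accounts for the size or direction of this step.

Among the compounds shown here, the single step replaces the whole 4-methoxyphenyl group, so it cannot tell whether the result comes from losing the methoxy group, gaining the chlorine, or the different placement on the phenyl ring. From the compounds shown here alone, it also remains open how a plain phenyl or an amine-bearing phenyl would read at this carbon, and whether 3-chlorophenyl gives a similar step alongside 3-cyanophenyl or 3-chloro-4-fluorophenyl on the sulfonyl sulfur.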